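From Amide to Urea: What the Growth Assay May Show

A few compounds are considered here, and "the series" means these few. Any claim that something is new, unique, unknown or untested is made for them only; others in the source may bear on it.

compound 1: `COc1cc(-c2nn(-c3cccc(NC(=O)c4cccc(C(F)(F)F)c4)c3)cc2-c2ccncc2)ccc1Cl`, 1560 nM
compound 2: `O=C(Nc1cccc(-n2cc(-c3ccncc3)c(-c3ccc(Cl)c(O)c3)n2)c1)Nc1ccc(Cl)c(Cl)c1`, 1030 nM

In a functional assay on SK-MEL-2 cells (Homo sapiens) for inhibition, read by sulforhodamine B assay, with a stated time of 48 h (on this read-out lower numbers stand for stronger inhibition of growth and higher numbers for weaker inhibition of growth), compound 1 gives 1560 nM and compound 2 gives 1030 nM. Compound 1 holds the higher of the two numbers, but the gap to compound 2 lies within the scatter. Compound 3 `COc1cc(-c2nn(-c3cccc(NC(=O)Nc4cccc(C(F)(F)F)c4)c3)cc2-c2ccncc2)ccc1Cl` has not been measured. It differs from compound 1 by (3-(trifluoromethyl)phenyl)amino in place of 3-(trifluoromethyl)phenyl on a carbonyl carbon: an amide becomes a urea. Going by the values given here, no measured pair isolates this change, but compound 2, itself a urea, gives 1030 nM, which sits within the scatter of compound 1, so the expected step of a 1.3-fold lower number from compound 1 to compound 3 (0.11 log units; within the scatter) is none beyond the scatter. Compound 3 is estimated at 1200 nM, between 450 nM and 3200 nM.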

Compound 3, concentration for 50% growth inhibition: 970 nM
For compound 3 the middle estimate is 1.2-fold (0.09 log units) above the measured one; low and high end bracket the measured number.
By their numbers in this assay, from the lowest: compounds 3, 2 and 1 (each within the scatter of the next).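

In this assay, putting (3-(trifluoromethyl)phenyl)amino in place of 3-(trifluoromethyl)phenyl on a carbonyl carbon gives a 1.6-fold lower number from compound 1 to compound 3 (0.21 log units; within the scatter) as the amide becomes a urea. Going by these compounds alone, this pair is the first to isolate the change, and it shows that the urea keeps growth inhibition in the same range as the amide at this position. Going by these compounds, whether another link here, such as a sulfonamide or a thiourea, would move the number beyond the scatter stays open. Nothing available explains why the amide and urea read so alike.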